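This account rests on a few compounds, and the source may have more. Where it says the series, first, only, none or still open, it means among the compounds named here.

Measured so far:
compound 1, `CO[C@]1(c2cc(F)cc(S(=O)(=O)c3ccc(/C(C)=N/OCC#N)cc3)c2)CCO[C@@H](C)C1`: 60 nM
compound 2, `CC(C)/C(=N\O)c1ccc(Sc2cc(F)cc(C3CCOCC3)c2)cc1`: 300 nM
compound 3, `Fc1cc(Sc2ccc3c(c2)CC/C3=N\OCc2ccncc2)cc(C2CCOCC2)c1`: 90 nM

In a functional assay (blood) for inhibition, with Homo sapiens as the target (a higher number here means a weaker inhibitor, a lower number a stronger inhibitor), compound 2 stands highest of the three numbers; its nearest neighbour is compound 3 and its furthest compound 1, and both gaps lie beyond the scatter. Compound 4, `C/C(=N\OC(C)C)c1ccc(Sc2cc(F)cc(C3CCOCC3)c2)cc1`, has not yet been tested. It differs from compound 2 in one place: a group of 7 heavy atoms (5 carbon, 1 nitrogen, 1 oxygen; no ring) in place of a group of 6 heavy atoms (4 carbon, 1 nitrogen, 1 oxygen; no ring), on an aromatic carbon. The group that leaves carries one hydrogen-bond donor, the group that enters carries none. Compound 1 and compound 3 each give a lower number than compound 2. The step is therefore expected to run downward, beyond the scatter, at a 2.5-fold lower number from compound 2 to compound 4 (0.40 log units; beyond the scatter). Compound 4 is expected to give about 120 nM, within a range from 50 nM to 300 nM.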

Compound 4, half-maximal inhibitory concentration: 920 nM
The estimate for compound 4 lay 7.7-fold (0.88 log units) below the measured number, and the stated range ends below it.
By their numbers in this assay, from the lowest: compounds 1 and 3 (each within the scatter of the next); then compound 2; then compound 4.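

In this assay the exchange on this aromatic carbon, para to a large group, gives a 3.1-fold higher number from compound 2 to compound 4 (0.49 log units; beyond the scatter) and so raises the number rather than lowering it. Within this pair, the group carrying one hydrogen-bond donor holds the lower number, and the position is shown to respond to this change. Nothing available explains the rise.

The two groups differ in both donor count and heavy-atom count, so the compounds shown leave open which difference matters. Going by these compounds, how an amine or a carboxylic acid would read at this position in this assay also remains open.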